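Working notes: three measured analogues and one still to measure

The source may hold more compounds than are shown below. What is called first, only, known or untested is meant among the compounds shown, and "the series" means these compounds.

Measured so far:
compound 1 `CCCCc1cnc(Cc2ccc(-c3ccccc3C(=O)O)cc2)[nH]1`: > 10000 nM
compound 2 `CCCCc1cnc(CCCc2ccc(-c3ccccc3C(=O)O)cc2)[nH]1`: 5600 nM
compound 3 `COc1ccc(Cc2cnc(CCc3ccc(-c4ccccc4C(=O)O)cc3)[nH]2)cc1`: 5360 nM

In an in vitro functional assay on cells for agonist activity at Bombesin receptor subtype-3 (Homo sapiens), read by luminescence and calcium flux (a higher number here means that more compound is needed for the effect, a lower number that less compound is needed), compound 3 gives 5360 nM, the lower of the two numbers in hand, though its gap to compound 2 lies within the usual scatter. The result for compound 1 is a limit of the assay, not a number (the limit of > 10000 nM in this assay, at which 1 of the 3 values shown sits).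

Compound 4 `CC(C)CCc1cnc(CCc2ccc(-c3ccccc3C(=O)O)cc2)[nH]1` differs from compound 3 in one place: isobutyl in place of 4-methoxyphenyl on a saturated chain carbon bound to an aromatic carbon. Going by the values given here, no step between measured compounds is available to guide the size of this change. The step of a 1.1-fold higher number from compound 3 to compound 4 (0.05 log units; within the scatter) is expected to be small, no more than the scatter, in no fixed direction. Compound 4 is therefore estimated at 6000 nM, within 2000 nM to 20000 nM.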

Compound 4, half-maximal effective concentration: 119 nM
The estimate for compound 4 lay 50-fold (1.70 log units) above the measured number; measured number outside the range, below it.
By their numbers in this assay, from the lowest: compound 4; then compounds 3 and 2 (each within the scatter of the next). At a limit, above all of these: compound 1.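

In this assay this position, on a saturated chain carbon bound to an aromatic carbon, proves highly sensitive to the group it carries: isobutyl in place of 4-methoxyphenyl gives a 45-fold lower number from compound 3 to compound 4 (1.65 log units; beyond the scatter) and so opens a clear gap in the series. The group without a ring, with fewer heavy atoms and no hydrogen-bond acceptor, gives the lower number. Nothing in hand accounts for the size of this step.

As far as these compounds go, it remains open whether the ring or its methoxy group drives the difference. A plain benzyl or a cyclohexylmethyl group at this place would separate the two.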